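Methylamino for methoxy on a phenyl-bearing nucleoside core

This account rests on a few compounds, and the source may have more. Where it says the series, first, only, none or still open, it means among the compounds named here.

Measured so far in a functional assay on K562 cells (Homo sapiens), read by MTT assay, with a stated time of 72 h; on this read-out lower numbers stand for stronger inhibition and higher numbers for weaker inhibition:
Compound 1 `COc1ncnc2c1c(-c1ccsc1)cn2[C@@H]1O[C@H](CO)[C@@H](O)[C@H]1O` gives 3450 nM.
Compound 2 `CSc1ncnc2c1c(-c1ccccc1)cn2[C@@H]1O[C@H](CO)[C@@H](O)[C@H]1O` reaches only the assay limit, > 20000 nM.
Compound 3 `COc1ncnc2c1c(-c1ccccc1)cn2[C@@H]1O[C@H](CO)[C@@H](O)[C@H]1O` also sits at the assay limit, > 20000 nM.

Compound 3 therefore stands at the upper boundary of what this assay reports: its value is a limit, not a number, and compound 1 is the only one of the three with a measured value. Two of the three results coincide at the limit of > 20000 nM in this assay, at which 2 of the 3 values shown sit. The next compound, compound 4 `CNc1ncnc2c1c(-c1ccccc1)cn2[C@@H]1O[C@H](CO)[C@@H](O)[C@H]1O`, differs from compound 3 by methylamino in place of methoxy on an aromatic carbon.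

Going by the values given here, only one measured step touches the same place: a step that the two limits leave unreadable from compound 2 to compound 3. Both of its ends are limits, so it gives no direction and no size. The other step, an at least 5.7-fold higher number from compound 1 to compound 3 (0.76 log units; beyond the scatter), concerns the aryl group and not the group that changes here. Nothing measured therefore tells whether methylamino moves the number. The most cautious expectation is that compound 4 stays near the limit where compound 3 stands. Compound 4 is estimated at 20000 nM, within 5000 nM to 60000 nM. The expected step is a number no higher from compound 3 to compound 4 (the limit leaves the size open), most likely not readable beyond the scatter.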

Compound 4, half-maximal inhibitory concentration: > 20000 nM
Compound 4 ended at the assay's limit (the forecaster's own chance of this, stated with the estimate: 60%); the middle value sits exactly at the limit.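

Compound 4 also gives only a limit, so its comparisons with compound 2 and compound 3 cannot be read as steps, because all three sit at the same boundary: the limit of > 20000 nM in this assay, at which 3 of the 4 values shown sit.

From the compounds shown here alone, whether methylamino, methoxy and methylsulfanyl truly differ on the phenyl-bearing compounds stays open, as does what methylamino would do in place of methoxy in compound 1.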